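Compound 2 loses its bromo group

The compounds below may be only part of what the source reports. "The series", "measured", "known", "first", "only" and "open" are said of these compounds alone.

Going by the values given here, in a functional assay on PC-3 cells (Homo sapiens) for inhibition, read by MTT assay, with a stated time of 48 h (on this read-out lower numbers stand for stronger inhibition and higher numbers for weaker inhibition), only two compounds have numbers so far. Compound 1 `CCOC(=O)c1ccc(Nc2nnc(Cl)c(Nc3cc(OC)c(OC)c(OC)c3)n2)cc1` gives 58500 nM. Among the compounds with values here, compound 2 `COc1cc(Nc2nc(Nc3ccc(Br)cc3)nnc2Cl)cc(OC)c1OC` gives 8990 nM, the lower of the two, and compound 1 is its only neighbour on this scale.

Compound 3 `COc1cc(Nc2nc(Nc3ccccc3)nnc2Cl)cc(OC)c1OC` has not been measured. It departs from compound 2 by a single change, hydrogen in place of bromo on an aromatic carbon, para to a large group: hydrogen in place of bromo on an aromatic carbon.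

Within the data shown here, one measured step bears on this: a 6.5-fold lower number from compound 1 to compound 2 (0.81 log units; beyond the scatter). The bromo group that leaves here is the group that entered in that step, so the substituent on this carbon has already moved the number beyond the scatter. Among the measured compounds shown here, no measured compound carries hydrogen on this carbon, so the direction remains a cautious call. A modest step towards a higher number is expected, smaller than the measured one. The estimated step is a 2.1-fold higher number from compound 2 to compound 3 (0.32 log units; beyond the scatter). The estimate for compound 3 is 19000 nM, with an expected range of 6000 nM to 55000 nM.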

Compound 3, half-maximal inhibitory concentration: 9750 nM
For compound 3 the middle estimate is 1.9-fold (0.29 log units) above the measured one; measured number inside the range.
By their numbers in this assay, from the lowest: compounds 2 and 3 (each within the scatter of the next); then compound 1.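

In this assay, bromo and hydrogen on this aromatic carbon, para to a large group, cannot be told apart (a 1.1-fold higher number from compound 2 to compound 3 (0.04 log units; within the scatter)), so the bromo group is not needed for the lower number seen with compound 2. The step with hydrogen in place of ethoxycarbonyl is also beyond the scatter (a 6.0-fold lower number from compound 1 to compound 3 (0.78 log units; beyond the scatter)), which sets compound 1 apart from both compound 2 and compound 3 and ties the higher number, among these three compounds, to the ethoxycarbonyl group rather than to anything bromo adds. The compounds shown offer no measurement that would explain this difference.

Three substituents on one carbon do not show whether the higher number is specific to the ethoxycarbonyl group, or would also come with a carboxylic acid, a primary amide or a methoxycarbonyl group at this place. Also open, from the compounds shown here alone, is whether a methoxy group, a fluoro group or an amine on this carbon would stay level with compound 2 and compound 3, or would move the number in either direction.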